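A few compounds are considered here, and "the series" means these few. Any claim that something is new, unique, unknown or untested is made for them only; others in the source may bear on it.

Three compounds share one core and differ only in the group on one aromatic carbon. In a functional assay on the whole organism (strain Swiss albino) for inhibition, with Mus musculus as the target, in the formalin test, with a stated time of 30 min, at a dose of 100 mg/kg by the intraperitoneal route (on this read-out higher numbers stand for more inhibition at the one dose given (going by the name of the read-out) and lower numbers for less inhibition), compound 1 `Nn1c(CCc2ccc(O)cc2)nnc1SCC(=O)N1N=C(c2cccs2)CC1c1ccc(F)cc1` gives 78.3%. Compound 2 `Nn1c(CCc2ccc(O)cc2)nnc1SCC(=O)N1N=C(c2cccs2)CC1c1ccc(Cl)cc1` gives 72.1%. Compound 3 `Cc1ccc(C2CC(c3cccs3)=NN2C(=O)CSc2nnc(CCc3ccc(O)cc3)n2N)cc1` gives 42.5%, the lowest of the three. The step of a number 6.2 percentage points lower from compound 1 to compound 2 (within the scatter) stays within the scatter, whereas a number 35.8 percentage points lower from compound 1 to compound 3 (beyond the scatter) and a number 29.6 percentage points lower from compound 2 to compound 3 (beyond the scatter) both lie beyond it. Compound 4 `CN(C)c1ccc(C2CC(c3cccs3)=NN2C(=O)CSc2nnc(CCc3ccc(O)cc3)n2N)cc1` differs from compound 3 by dimethylamino in place of methyl on an aromatic carbon. Within the data shown here, no measured step exchanges methyl for dimethylamino, so no step bears directly on this change; the two steps reaching compound 3 swap a halogen for methyl instead. With no guide, the expected step is a number 5.5 percentage points higher from compound 3 to compound 4 (within the scatter). The estimate for compound 4 is 48%, with a range from 28% to 68%.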

Compound 4, a percentage reported as inhibition, in the whole organism at one dose (the size of the read-out at that dose, not a potency): 38.9%
For compound 4 the middle estimate is 9.1 percentage points above the measured one; the range from low to high includes it.
By their numbers in this assay, from the lowest: compounds 4 and 3 (each within the scatter of the next); then compounds 2 and 1 (each within the scatter of the next).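

In this assay, dimethylamino at the aromatic carbon para to a large group gives a step of a number 3.6 percentage points lower from compound 3 to compound 4 (within the scatter), so the added nitrogen and hydrogen-bond acceptor leave it indistinguishable from methyl. Against the halogens it shows a number 33.2 percentage points lower from compound 2 to compound 4 (beyond the scatter) and a number 39.4 percentage points lower from compound 1 to compound 4 (beyond the scatter), which places both non-halogen groups apart from chloro and fluoro, and none of these four compounds goes against that split. Nothing measured here accounts for this split. Going by these compounds, whether bromo, methoxy or a carboxylic acid at this carbon would sit with the halogens or with methyl and dimethylamino stays open.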